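Removing a Trifluoromethyl Group from a Stable Compound

This account rests on a few compounds, and the source may have more. Where it says the series, first, only, none or still open, it means among the compounds named here.

This study asks how much of a compound remains after incubation with human liver microsomes, a read-out used as a stand-in for the body's ability to break a compound down. Compound 1 `Cn1c(C(F)(F)F)ccc(NCc2cc3cc(Cl)ccc3[nH]c2=O)c1=O` is the starting point. In an ADME assay on microsomes from liver (Homo sapiens) for metabolic stability, with a stated time of 30 min (on this read-out lower numbers stand for a less stable compound and higher numbers for a more stable compound), compound 1 gives 85%. Two related compounds were also measured: compound 2 `C[C@H](Nc1ccc(C#N)n(C)c1=O)c1cc2cc(Cl)c(O[C@H](C)c3ccccn3)cc2[nH]c1=O` gives 70%, and compound 3 `C[C@H](Nc1ccc(C#N)n(C)c1=O)c1cc2cc(Cl)c(OCC3CC3)cc2[nH]c1=O` gives 82%. The number of compound 1 thus stands with that of compound 3, within the scatter of the method, while it lies clearly beyond the number of compound 2.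

Within the data shown here, the only measured step between neighbours is a number 12 percentage points higher from compound 2 to compound 3 (beyond the scatter). That step alters the group on the oxygen at the far side of the shared core, not the ring that carries the trifluoromethyl group, so it offers little guidance for the change studied here.

Compound 4 `Cn1cccc(NCc2cc3cc(Cl)ccc3[nH]c2=O)c1=O` differs from compound 1 in one place: hydrogen in place of trifluoromethyl on an aromatic carbon. Among the measured compounds shown here, no measured step touches this position, so the expectation rests on compound 1 alone. The likeliest outcome is a number close to that of compound 1, with some chance of a modest fall; the expected step is a number 10 percentage points lower from compound 1 to compound 4 (within the scatter). Compound 4 is therefore estimated at 75%, within a range from 55% to 90%.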

Compound 4, percent of the compound remaining in the Homo sapiens assay: 90%
For compound 4 the middle estimate is 15 percentage points below the measured one; measured number inside the range.
By their numbers in the Homo sapiens assay, from the lowest: compound 2; then compounds 3, 1 and 4 (each within the scatter of the next).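

At this position, on an aromatic carbon next to the ring nitrogen, the trifluoromethyl group can give way to a single hydrogen with no change beyond the scatter in the Homo sapiens assay: the result is a number 5 percentage points higher from compound 1 to compound 4 (within the scatter). In a physicochemical assay for solubility (on this read-out lower numbers stand for lower solubility and higher numbers for higher solubility), compound 1 gives < 100 nM, which is a limit of the assay and not a number. In the physicochemical assay compound 4 gives 54000 nM, and the same change thus comes with an at least 540-fold higher number from compound 1 to compound 4 (2.73 log units; beyond the scatter), so two read-outs that might be expected to move together part ways here, with one staying level and the other shifting greatly.

Going by these compounds, only hydrogen and trifluoromethyl can be compared at this position, so it remains open how a methyl group, a chlorine atom or an amine there would fare in the Homo sapiens assay and in the physicochemical assay. On these data alone, it also remains open whether the same change would give the same pair of results on a compound carrying other groups elsewhere, such as the cyclopropylmethyl group of compound 3.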